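This account rests on a few compounds, and the source may have more. Where it says the series, first, only, none or still open, it means among the compounds named here.

Series notes, lipophilicity.

Three compounds of the series have been run in a physicochemical assay for lipophilicity; on this read-out lower numbers stand for lower lipophilicity and higher numbers for higher lipophilicity. Compound 1 `CN1CCN(CCCS(=O)(=O)c2ccc3nc(NC(=O)NC(=O)c4cc(C5CC5)ccc4Cl)sc3c2)CC1` gives 2.9 in this assay. Compound 2 `CN1CCC(S(=O)(=O)c2ccc3nc(NC(=O)NC(=O)c4cc5c(cc4Cl)CCN5C)sc3c2)CC1` gives 2.8 in this assay. Compound 3 `CC(C)NCCS(=O)(=O)c1ccc2nc(NC(=O)NC(=O)c3ccccc3Cl)sc2c1` gives 2.3 in this assay, the lowest of the three numbers; the values of compound 2 and of compound 1 both stand above it by more than the usual scatter of repeat measurements, with compound 1 the further of the two. No pair among these three differs in only one place, so no single step between measured compounds can be read off.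

Compound 4 `CN(C)CCCS(=O)(=O)c1ccc2nc(NC(=O)NC(=O)c3ccccc3Cl)sc2c1` is the next member to go into this assay. Within the data shown here, its only difference from compound 3 is (dimethylamino)methyl in place of isopropylamino on a saturated chain carbon, two bonds along the chain from a sulfonyl sulfur. The two compounds share every atom and differ only in how the chain atoms are joined. Among the measured compounds shown here, no measured pair shows this kind of rearrangement, so the expectation rests on compound 3 alone: the step of a number 0.10 log units higher from compound 3 to compound 4 (within the scatter) is expected to be small, not beyond the scatter, with no firm direction. On that basis compound 4 is estimated at 2.4 in this assay, with a range from 2 to 2.8.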

Compound 4, distribution coefficient: 1.7
Compound 4: middle estimate off by 0.70 log units, on the high side; measured number outside the range, below it.
By their numbers in this assay, from the lowest: compound 4; then compound 3; then compounds 2 and 1 (each within the scatter of the next).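

In this assay this position does not treat the same atoms alike when they are joined differently: (dimethylamino)methyl in place of isopropylamino, on a saturated chain carbon, two bonds along the chain from a sulfonyl sulfur, gives a number 0.60 log units lower from compound 3 to compound 4 (beyond the scatter) with no atom gained or lost. Among these compounds, this is the first single-place comparison, and it shows that the read-out can move beyond the scatter on a change of connectivity alone. The change has several parts at once, since 2-(isopropylamino)ethyl becomes 3-(dimethylamino)propyl, and isopropylamino with 1 hydrogen-bond donor gives way to a group with 0 hydrogen-bond donors, and nothing measured here ties the step to any one of these parts.

Open, going by these compounds, is which part of the change carries the step: a 3-(isopropylamino)propyl chain or a 2-(dimethylamino)ethyl chain on the same core would separate chain length from the form of the amine. Also open, on these data alone, is whether a step of this size holds when the chlorine-bearing ring carries further groups, as in compound 1 and compound 2.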